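The compounds below may be only part of what the source reports. "The series", "measured", "known", "first", "only" and "open" are said of these compounds alone.

Compound 2 `O=C1C(=O)N(CN(c2ccccc2)c2ccccc2)c2ccccc21` and compound 1 `O=C1C(=O)N(CN(c2ccccc2)c2ccccc2)c2cccc(Cl)c21` share one core and differ at a single spot, (chloro in place of hydrogen on an aromatic carbon). In an ADME assay on 184B5 cells (Homo sapiens) for cytotoxicity, read by sulforhodamine B assay, with a stated time of 48 h (a lower number here means a stronger inhibitor of growth, a higher number a weaker inhibitor of growth), compound 2 gives 33700 nM, and compound 1 gives 96800 nM, so that the change brings a 2.9-fold higher number from compound 2 to compound 1 (0.46 log units; beyond the scatter). Compound 3 `CN(C)CN1C(=O)C(=O)c2ccccc21` is built on another core; the difference between the two cores is not broken down here. In this assay compound 3 gives 73700 nM, which lies within the scatter of the number for compound 1 and beyond the scatter from the number for compound 2. Compound 4 `CN(C)CN1C(=O)C(=O)c2c(Cl)cccc21` stands to compound 3 as compound 1 stands to compound 2, the alteration being (chloro in place of hydrogen on an aromatic carbon), at a place described in the same words as before, so it is the same change. For the measured compounds named here, for compound 4 the expected step is a 2.2-fold higher number from compound 3 to compound 4 (0.34 log units; beyond the scatter), resting on the single earlier instance, a 2.9-fold higher number from compound 2 to compound 1 (0.46 log units; beyond the scatter), with the caution that one prior example is a thin basis. Compound 4 is therefore estimated at 160000 nM in this assay, with a likely range from 70000 nM to 380000 nM.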

Compound 4, concentration for 50% growth inhibition: 130000 nM
Estimate against measurement, compound 4: 1.2-fold (0.09 log units) above; measured number inside the range.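

In this assay the replacement of hydrogen by chloro gives a 1.8-fold higher number from compound 3 to compound 4 (0.25 log units; within the scatter) and so, taken alone, does not stand clear of repeat measurement on this core. Set beside the earlier step, the result gives no sign that the two cores respond differently to the change: the same change on two cores in this assay, a 2.9-fold higher number (0.46 log units; beyond the scatter) from compound 2 to compound 1 and a 1.8-fold higher number (0.25 log units; within the scatter) from compound 3 to compound 4, 1.6-fold (0.21 log units) apart, within the scatter of two such steps. For the compounds shown here, this agrees with the change carrying across the two cores at a similar size, but it rests on only two pairs, one of them within the scatter, so it does not establish a real effect on the second core, fix the size of the step, or extend to any other core.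

The compounds shown leave open whether another group in place of the chloro, such as fluoro, methoxy, an amine or a carboxylic acid, would carry across these two cores in the same way. They also leave open how chloro would behave on a different aromatic carbon of the same ring.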